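Swapping tert-butyl for phenyl: what happens to clearance?

The compounds below may be only part of what the source reports. "The series", "measured", "known", "first", "only" and "open" are said of these compounds alone.

In an ADME assay on liver for metabolic stability, with Liver microsome (Homo sapiens) as the target, read by LC-MS, using microsomes (on this read-out lower numbers stand for slow clearance and higher numbers for fast clearance), compound 2 `CC(C)(C)[C@@H](O)C(=O)N1C[C@@H]2C[C@@H]2[C@H]1C(=O)NCc1cc(Cl)ccc1-n1cnnn1` gives < 15 mL.min-1.g-1, which is a limit of the assay and not a number. Compound 2 thus stands at the limit of < 15 mL.min-1.g-1 in this assay, at which 1 of the 3 values shown sits. Compound 3 `CC(C)(C)[C@@H](O)C(=O)N1CSC(C)(C)[C@H]1C(=O)NCc1cc(Cl)ccc1-n1cnnn1` also carries tert-butyl, yet it gives 360 mL.min-1.g-1, so this group does not bring slow clearance in every compound measured here.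

Compound 4 `O=C(NCc1cc(Cl)ccc1-n1cnnn1)[C@@H]1[C@H]2C[C@H]2CN1C(=O)[C@H](O)c1ccccc1` differs from compound 2 by one change, with phenyl in place of tert-butyl on a saturated chain carbon bound to a carbonyl carbon and an oxygen on a saturated carbon. Among the measured compounds shown here, no measured pair shows this change alone. Compound 1 `O=C(NCc1cc(Cl)ccc1-n1cnnn1)[C@@H]1C[C@@H]2C[C@@H]2N1C(=O)[C@H](O)c1cccc(Cl)c1` has a six-membered aromatic ring in that place, though its structure differs in other ways, and it gives > 500 mL.min-1.g-1, which is also a limit of the assay.

On that single hint, the expected change in this assay is a step of an at least 6.6-fold higher number from compound 2 to compound 4 (0.82 log units; beyond the scatter), towards faster clearance and beyond the usual scatter. For compound 4 the estimated value is 100 mL.min-1.g-1, with an expected range of 25 mL.min-1.g-1 to 400 mL.min-1.g-1.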

Compound 4, intrinsic clearance in microsomes: 61 mL.min-1.g-1
Compound 4: middle estimate off by 1.6-fold (0.21 log units), on the high side; measured number inside the range.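

In this assay, among the compounds shown here, this is the first direct reading of the change at this position: phenyl in place of tert-butyl on a saturated chain carbon bound to a carbonyl carbon and an oxygen on a saturated carbon gives an at least 4.0-fold higher number from compound 2 to compound 4 (0.60 log units; beyond the scatter), towards faster clearance. Compound 2 stands at a limit of the assay and not at a number: the limit of < 15 mL.min-1.g-1 in this assay, at which 1 of the 4 values shown sits. The true step may therefore be larger than the one printed, but the position clearly responds to this swap, and compound 4 gives a real number, 61 mL.min-1.g-1.

From the compounds shown here alone, this is a single pair on a single core, so it remains open whether the same swap would give a similar step on another core. Going by these compounds, it is also open whether a cyclohexyl or pyridyl group here would read closer to tert-butyl or to phenyl.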